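From amino to methylamino on compound 1

The compounds below may be only part of what the source reports. "The series", "measured", "known", "first", "only" and "open" are said of these compounds alone.

- compound 1 `CCc1ccc(Cl)cc1-n1cc(-c2cc(N)ncn2)cc1C(N)=O` with 12500 nM
- compound 2 `Cc1ccc(Cl)cc1-c1cn(-c2ncnc3[nH]ccc23)cc1C(N)=O` with "not determined" (no result reported)

Going by the values given here, in an ADME assay on the whole organism (strain Balb) for pharmacokinetics, with Mus musculus as the target, read by LC-MS, at a dose of 10 mg/kg by the oral route (a higher number here means more compound in the circulation at the dose given, a lower number less compound in the circulation), compound 1 gives 12500 nM as the only number at hand, and with no result reported for compound 2 it cannot be ranked against anything. Compound 3 `CCc1ccc(Cl)cc1-n1cc(-c2cc(NC)ncn2)cc1C(N)=O` departs from compound 1 by one change (methyl in place of hydrogen on a nitrogen on an aromatic ring) with methyl in place of hydrogen on a nitrogen on an aromatic ring, which reads as amino to methylamino. Among the compounds with values here, no measured pair shows this change, so the expectation rests on the structural difference alone. In this assay no step beyond the usual scatter is expected, with a slight lean downward. The expected 1.4-fold lower number from compound 1 to compound 3 (0.14 log units; within the scatter) is an estimate and stays within that scatter. For compound 3 the estimated value is 9000 nM with an expected range from 3000 nM to 20000 nM once it is measured.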

Compound 3, maximal plasma concentration: 1600 nM
Estimate against measurement, compound 3: 5.6-fold (0.75 log units) above; the measured number lies below the stated range.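

In this assay the amino group of the 6-aminopyrimidin-4-yl substituent proves sensitive to change: methyl in place of hydrogen on this nitrogen gives a 7.8-fold lower number from compound 1 to compound 3 (0.89 log units; beyond the scatter) and so moves the number beyond the usual scatter. A single added carbon at this place is therefore enough to separate the two compounds, and this first readable step in the series favours the unsubstituted amino group of compound 1. Nothing at hand bears on what lies behind the drop.

Going by these compounds, whether the number keeps falling with a longer chain on this nitrogen, such as ethylamino, or with dimethylamino, remains open. Also open, on these data alone, is whether replacing the amino group with a hydroxyl or a fluorine would match compound 1 or fall nearer to compound 3.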